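The source may report more compounds than this note shows. Statements on the series, on what has been measured and on what is new or still open speak of the compounds shown alone.

Measured in a functional assay on HCT-116 cells (Homo sapiens) for inhibition, read by MTT assay, with a stated time of 72 h (a lower number here means a stronger inhibitor, a higher number a weaker inhibitor), so far:
- compound 1 `O=C1C=CC(O)(c2cc3ccc(F)cc3n2S(=O)(=O)c2ccccc2)C=C1` gives 30 nM here
- compound 2 `Cc1ccc(S(=O)(=O)n2c(C3(O)C=CC(=O)C=C3)cc3ccccc32)cc1` gives 30 nM here
- compound 3 `COC(=O)CCc1ccc(S(=O)(=O)n2c(C3(O)C=CC(=O)C=C3)cc3ccccc32)cc1` gives 30 nM here

Compound 3 stands level with compound 1 and compound 2 at the digits shown, so these values give no order within the series. Compound 4 (`COC(=O)CCc1ccc(S(=O)(=O)n2c(C3(O)C=CC(=O)C=C3)cc3ccc(F)cc32)cc1`) differs from compound 3 in one place. The change is fluoro in place of hydrogen on an aromatic carbon and, in words, it is fluoro in place of hydrogen on an aromatic carbon.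

Within the data shown here, the only measured single-place step is no change at the digits printed from compound 2 to compound 3 (within the scatter) and it lies within the scatter. That step puts (methoxycarbonyl)methyl in place of hydrogen on a saturated chain carbon, so it does not test the fluoro change directly. Among the measured compounds shown here, no measured step isolates fluoro in place of hydrogen. Compound 1 carries a fluoro and gives 30 nM while compound 2 lacks it and gives 30 nM here, but these two compounds differ in more than one place, so the comparison is only indirect.

No step beyond the scatter is therefore expected, and the estimated no change at the digits printed from compound 3 to compound 4 (within the scatter) has no favoured direction. In this assay the estimated value for compound 4 is 30 nM with an expected range of 15 nM to 60 nM around it.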

Compound 4, half-maximal inhibitory concentration: 30 nM
Compound 4: middle estimate and measured number agree at the digits printed; low and high end bracket the measured number.
By their numbers in this assay, from the lowest: compounds 1, 2, 3 and 4 (each within the scatter of the next).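

In this assay the fluoro in place of hydrogen on an aromatic carbon, meta to a fused ring and para to a fused ring, can now be read on its own, with no change at the digits printed from compound 3 to compound 4 (within the scatter) on a background that carries the 2-(methoxycarbonyl)ethyl group. The same group can now also be read with fluoro present, with no change at the digits printed from compound 1 to compound 4 (within the scatter). Each of the two changes therefore leaves the read-out flat in the presence of the other, at least on this pair of backgrounds, and no information on the reason for this is available.

The compounds shown leave open whether a different group on this aromatic carbon, such as an amine or a methoxy group, would shift the value, and whether a carboxylic acid in place of the methyl ester, or a longer chain, would do so. Among these compounds, with all four compounds level, the series so far holds no step beyond the scatter, so it does not yet show which parts of the structure the read-out depends on.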